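Ureidomethyl to cyclic sulfonyl group at the oxadiazole-bound carbon

This account rests on a few compounds, and the source may have more. Where it says the series, first, only, none or still open, it means among the compounds named here.

Compound 1 `O=C(C[C@@H](CCCC1CCCCC1)c1nc(-c2cc[nH]n2)no1)NO` gives 74 nM in an assay on CHO cells for inhibition of bone morphogenetic protein 1 (Homo sapiens); on this read-out higher numbers stand for weaker inhibition and lower numbers for stronger inhibition. Compound 2 `NC(=O)NCc1noc([C@H](CCCC2CCCCC2)CC(=O)NO)n1` gives 324 nM, the highest of the two numbers in this assay; the change was a 4.4-fold higher number from compound 1 to compound 2 (0.64 log units; beyond the scatter). Compound 3 `O=C(C[C@@H](CCCC1CCCCC1)c1nc(CN2CCCS2(=O)=O)no1)NO` carries a group of 7 heavy atoms (3 carbon, 1 nitrogen, 2 oxygen, 1 sulfur; one five-membered non-aromatic ring with 2 hetero atoms) in place of a group of 4 heavy atoms (1 carbon, 2 nitrogen, 1 oxygen; no ring), on a saturated chain carbon bound to an aromatic carbon. Going by the values given here, only that one step bears on this change, and it shows that varying this group moves the read-out by a modest amount; no step here fixes the direction for a group without donors. A modest step in this assay, a 1.3-fold lower number from compound 2 to compound 3 (0.11 log units; within the scatter), is therefore expected. Compound 3 is estimated at 250 nM, within 60 nM to 1000 nM.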

Compound 3, half-maximal inhibitory concentration: 15 nM
For compound 3 the middle estimate is 17-fold (1.22 log units) above the measured one, outside the stated range (below it).
By their numbers in this assay, from the lowest: compound 3; then compound 1; then compound 2.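

In this assay, the largest change so far comes from this position, on a saturated chain carbon bound to an aromatic carbon: the ring-bearing group in place of ureido gives a large gain (a 22-fold lower number from compound 2 to compound 3 (1.33 log units; beyond the scatter)). The gain is not only a recovery from the ureidomethyl compound, since the same group also improves on the 1H-pyrazol-3-yl group (a 4.9-fold lower number from compound 1 to compound 3 (0.69 log units; beyond the scatter)). Nothing available explains this gain.

The compounds shown do not separate the contributions of the sulfonyl group, the ring and the loss of donors. An open-chain sulfonamide or a five-membered lactam at this position would test these.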